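From 4-bromobenzyl to 2,4-difluorobenzyl: halogen change on the benzyl ring

A few compounds are considered here, and "the series" means these few. Any claim that something is new, unique, unknown or untested is made for them only; others in the source may bear on it.

Compound 1 (`Clc1ccc(CSc2nnc(-c3cnccn3)n2-c2ccccc2)cc1`) and compound 2 (`Brc1ccc(CSc2nnc(-c3cnccn3)n2-c2ccccc2)cc1`) share one core and differ in a single halogen. In a functional assay on HeLa cells (Homo sapiens) for antiproliferative activity, read by MTT assay, with a stated time of 48 h (a lower number here means a stronger inhibitor, a higher number a weaker inhibitor), compound 1 reads > 50000 nM, which is a limit and not a number. Within the data shown here, compound 2 gives 8630 nM, the only true number so far.

Compound 3 (`Fc1ccc(CSc2nnc(-c3cnccn3)n2-c2ccccc2)c(F)c1`) keeps the core and changes the benzyl group: 2,4-difluorophenyl in place of 4-bromophenyl on a saturated chain carbon bound to a sulfur.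

Among the measured compounds shown here, one measured step bears on this: bromo in place of chloro on an aromatic carbon gave an at least 5.7-fold lower number from compound 1 to compound 2 (0.76 log units; beyond the scatter), and its size is open-ended, resting on (the limit of > 50000 nM in this assay, at which 1 of the 2 values shown sits). Compound 3 also lacks the bromo, so a higher number in this assay is expected, though fluorine has not been tested here. The expected change is a 2.9-fold higher number from compound 2 to compound 3 (0.46 log units; beyond the scatter). For compound 3 the estimated value is 25000 nM, with an expected range of 7000 nM to 50000 nM.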

Compound 3, half-maximal inhibitory concentration: 12500 nM
Beside the measured number, compound 3's estimate is 2.0-fold (0.30 log units) above it, within the range that was stated.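

Bromine is not required at this position: in this assay, 2,4-difluorophenyl in place of 4-bromophenyl on a saturated chain carbon bound to a sulfur gives a 1.4-fold higher number from compound 2 to compound 3 (0.16 log units; within the scatter) and the activity is kept. The same group set against 4-chlorophenyl gives an at least 4.0-fold lower number from compound 1 to compound 3 (0.60 log units; beyond the scatter) and the reading of compound 1 is a limit, which leaves the size of that step open-ended: the limit of > 50000 nM in this assay, at which 1 of the 3 values shown sits. Among the three halogenated benzyl groups, compound 1 stands apart from compound 2 and compound 3, so the reading does not follow a simple trend in halogen size.

Still open, from the compounds shown here alone, is whether a phenyl ring carrying one fluorine reads like compound 3. Also open, going by these compounds, is how a benzyl ring bearing an amine or a carboxylic acid, or a longer chain before the ring, would read.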